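Swapping Methoxy for Chloro on the Benzyl Ring

The source may hold more compounds than are shown below. What is called first, only, known or untested is meant among the compounds shown, and "the series" means these compounds.

Of the compounds shown here, three have been measured in an assay for inhibition of Amine oxidase [flavin-containing] A (Rattus norvegicus); a lower number here means a stronger inhibitor, a higher number a weaker inhibitor. Compound 1 `Cc1ccc(COc2ccc(-c3nn(CCC#N)c(=O)o3)cc2)cc1` gives 25000 nM, compound 2 `Cc1ccc(COc2ccc(-c3nn(CCC#N)c(=S)o3)cc2)cc1` gives 10000 nM, and compound 3 `COc1cccc(COc2ccc(C3=NN(CCC#N)C(=O)CO3)cc2)c1` gives 32000 nM. Compound 3 thus carries the highest of the three numbers; its nearest neighbour is compound 1, whose value lies within the scatter of it, while compound 2 stands beyond the scatter with the lower number.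

Compound 4 `N#CCCN1N=C(c2ccc(OCc3cccc(Cl)c3)cc2)OCC1=O` has not yet been measured. It differs from compound 3 by chloro in place of methoxy on an aromatic carbon. Among the compounds with values here, no measured pair in this set shares that change, so no step can be read directly from the numbers, and the expectation rests on compound 3 alone. The estimated step is a 1.5-fold lower number from compound 3 to compound 4 (0.16 log units; within the scatter), expected to be small and not clearly beyond the scatter in either direction. In this assay compound 4 is therefore expected to give 22000 nM, with a range from 8000 nM to 60000 nM.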

Compound 4, half-maximal inhibitory concentration: 13000 nM
The estimate for compound 4 lay 1.7-fold (0.23 log units) above the measured number; low and high end bracket the measured number.
By their numbers in this assay, from the lowest: compounds 2, 4, 1 and 3 (each within the scatter of the next, the first and the last beyond it).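

In this assay, within the data shown here, chloro in place of methoxy gives a 2.5-fold lower number from compound 3 to compound 4 (0.39 log units; beyond the scatter), the first change in the set that can be read in one place alone. It shows that this position on the benzyl ring, meta to a large group, responds to the group it carries, though the step is modest. The swap replaces a methoxy of two heavy atoms and one hydrogen-bond acceptor with a chloro of one heavy atom and none, but no measurement here accounts for the lower number.

The compounds shown leave open whether a fluoro, a methyl or a hydroxyl at this place would lower the number further, or whether chloro would do the same on another carbon of the ring. They also leave open whether the same swap would give a similar step on the core of compound 1.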